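Swapping Chlorine for Bromine on the Hydroxyphenyl Ring

The compounds below may be only part of what the source reports. "The series", "measured", "known", "first", "only" and "open" are said of these compounds alone.

Compound 1 `O=C(CSc1nnc(-c2ccncc2)o1)N/N=C/c1ccc(F)cc1` gives 17800 nM in a functional assay on BGC-823 cells (Homo sapiens) for cytotoxicity, read by MTT assay, with a stated time of 48 h; on this read-out lower numbers stand for stronger inhibition and higher numbers for weaker inhibition.
Compound 2 `O=C(CSc1nnc(-c2ccncc2)o1)N/N=C/c1ccc(Br)cc1` gives 24500 nM.
Compound 3 `O=C(CSc1nnc(-c2ccncc2)o1)N/N=C/c1cc(Cl)cc(Cl)c1O` gives 6340 nM.

All three share one core and differ only in the aromatic ring attached to the carbon that is double-bonded to nitrogen. Among them compound 3 has the lowest number, and both of its steps lie beyond the scatter: a 2.8-fold lower number from compound 1 to compound 3 (0.45 log units; beyond the scatter) and a 3.9-fold lower number from compound 2 to compound 3 (0.59 log units; beyond the scatter). The shift from a singly halogenated ring to a 3,5-dichloro-2-hydroxyphenyl ring is therefore a modest gain in potency on this read-out.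

Compound 4 `O=C(CSc1nnc(-c2ccncc2)o1)N/N=C/c1cc(Br)cc(Br)c1O` takes that same ring one step further: 3,5-dibromo-2-hydroxyphenyl in place of 3,5-dichloro-2-hydroxyphenyl on a carbon with a double bond to nitrogen. Going by the values given here, the only measured step that bears directly on exchanging one halogen for another is a 1.4-fold higher number from compound 1 to compound 2 (0.14 log units; within the scatter), which stayed within the scatter. Among the compounds with values here, the change here touches two halogens rather than one, but there is no measured step involving a second halogen swap on this ring, so nothing in the data argues for a large movement in either direction.

The expectation is thus a step of a 1.0-fold higher number from compound 3 to compound 4 (0.01 log units; within the scatter), not beyond the scatter. Compound 4 is estimated at 6500 nM, with a range from 2500 nM to 16000 nM.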

Compound 4, half-maximal inhibitory concentration: 9610 nM
Compound 4: the middle estimate sits 1.5-fold (0.17 log units) below what was measured; measured number inside the range.
By their numbers in this assay, from the lowest: compounds 3, 4, 1 and 2 (each within the scatter of the next, the first and the last beyond it).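

In this assay, exchanging both chlorines of the ring for bromines gives (a 1.5-fold higher number from compound 3 to compound 4 (0.18 log units; within the scatter)), so this position accepts either pair of halogens without a change that can be told from the scatter. The new ring also gives a more mixed picture against the singly halogenated rings: compound 3 stood clear of both, but the dibromo ring separates from only one of them, with (a 2.5-fold lower number from compound 2 to compound 4 (0.41 log units; beyond the scatter)) beyond the scatter and (a 1.9-fold lower number from compound 1 to compound 4 (0.27 log units; within the scatter)) within it. The advantage of the 2-hydroxyphenyl rings therefore rests on firm ground against the 4-bromophenyl ring, but it is not secure against the 4-fluorophenyl ring once the chlorines are gone, and no supporting evidence accounts for any of these numbers.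

Every hydroxyphenyl ring shown carries two halogens and every other ring carries one halogen and no hydroxyl, so the share of the hydroxyl and the share of the halogens in these numbers cannot be separated. A plain 2-hydroxyphenyl ring, or a 3,5-dichlorophenyl ring, or a ring with methoxy or an amine in place of the hydroxyl, would each pull that question apart.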